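The source may report more compounds than this note shows. Statements on the series, on what has been measured and on what is new or still open speak of the compounds shown alone.

Working notes on the series. In a functional assay on MDA-MB-231 cells (Homo sapiens) for inhibition, read by CCK-8 assay, with a stated time of 48 h (a higher number here means a weaker inhibitor of growth, a lower number a stronger inhibitor of growth), compound 1 `Cc1ccccc1Nc1nc(Nc2ccc(N3CCCCC3)cc2)ncc1Cl` gives 19900 nM and compound 2 `CN1CCN(c2ccc(Nc3ncc(Cl)c(Nc4ccccc4)n3)nc2)CC1` gives 37400 nM; these two numbers lie within the scatter of each other, so neither compound can be placed ahead of the other, and only these two are measured. Compound 3 `Cc1cccc(Nc2nc(Nc3ccc(N4CCN(C)CC4)cn3)ncc2Cl)c1` differs from compound 2 by methyl in place of hydrogen on an aromatic carbon. Among the compounds with values here, no step between measured compounds covers this change, so the step from compound 2 to compound 3 is expected to stay within the scatter, estimated as a 1.2-fold lower number from compound 2 to compound 3 (0.10 log units; within the scatter). Compound 3 is expected to give 30000 nM in this assay, estimated range 10000 nM to 90000 nM.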

Compound 3, concentration for 50% growth inhibition: 5270 nM
The estimate for compound 3 lay 5.7-fold (0.76 log units) above the measured number; the whole stated range lies above it.
By their numbers in this assay, from the lowest: compound 3; then compounds 1 and 2 (each within the scatter of the next).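

In this assay, within the data shown here, phenyl to 3-methylphenyl gives a 7.1-fold lower number from compound 2 to compound 3 (0.85 log units; beyond the scatter), the first single-place change that can be read, and it lies beyond the scatter. A methyl of one heavy atom, with no hydrogen-bond donors or acceptors, meta to a large group, is thus enough to move the number at this position. Nothing on hand accounts for this step. Still open, as far as these compounds go, is whether an ethyl, a methoxy group or a chlorine in the same place gives a step of similar size. Also open, from the compounds shown here alone, is whether the same methyl gives a similar step on the core of compound 1.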